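The source may report more compounds than this note shows. Statements on the series, on what has been measured and on what is new or still open speak of the compounds shown alone.

Of the compounds shown here, three that share one core have been measured in an ADME assay on a cell-free system (plasma, Homo sapiens) for protein binding, with Plasma (Rattus norvegicus) as the target: compound 1 `O=C(O)c1cn(Cc2ccc(-n3cccn3)cc2)c2cccc(F)c2c1=O` gives 89.8%, compound 2 `Cc1ccn(-c2ccc(Cn3cc(C(=O)O)c(=O)c4c(F)cccc43)cc2)n1` gives 92.3% and compound 3 `O=C(O)c1cn(Cc2ccc(-n3ccnc3)cc2)c2cccc(F)c2c1=O` gives 88.1%. These numbers are best compared through the unbound fraction, the small share of compound left free. Seen that way, compound 3 cannot be separated from its neighbours: the measured steps are a 1.2-fold higher unbound fraction from compound 1 to compound 3 (0.07 log units; within the scatter) and a 1.5-fold higher unbound fraction from compound 2 to compound 3 (0.19 log units; within the scatter).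

Compound 4 `Cc1cn(-c2ccc(Cn3cc(C(=O)O)c(=O)c4c(F)cccc43)cc2)cn1` differs from compound 3 in a single place: methyl in place of hydrogen on an aromatic carbon. In words, this is methyl in place of hydrogen on an aromatic carbon, which turns 1H-imidazol-1-yl into 4-methyl-1H-imidazol-1-yl.

Going by the values given here, the closest precedent is the same swap on the 1H-pyrazol-1-yl group, a 1.3-fold lower unbound fraction from compound 1 to compound 2 (0.12 log units; within the scatter). Among the compounds with values here, it is the only methyl step available, it sits on a different group, and it does not rise above the noise, so it offers a weak guide. Within the data shown here, no methyl step on the 1H-imidazol-1-yl group has been measured.

A small move in the same direction is therefore expected, and the estimated step is a 1.3-fold lower unbound fraction from compound 3 to compound 4 (0.10 log units; within the scatter), which would not stand out from the scatter. For compound 4 the estimated value in this assay is 90.5%, with an expected range from 85.5% to 94%.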

Compound 4, plasma protein binding: 89.8%
Compound 4: the middle estimate sits 1.1-fold (0.03 log units) (unbound fraction) below what was measured; measured number inside the range.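

Placing methyl on this aromatic carbon of the 1H-imidazol-1-yl group leaves protein binding in this assay within the noise, with a 1.2-fold lower unbound fraction from compound 3 to compound 4 (0.07 log units; within the scatter). Until now the change had been seen only on the 1H-pyrazol-1-yl group, and this second example gives a step of similar size on a different group: the same change on two cores in this assay, a 1.3-fold lower unbound fraction (0.12 log units; within the scatter) from compound 1 to compound 2 and a 1.2-fold lower unbound fraction (0.07 log units; within the scatter) from compound 3 to compound 4, 1.1-fold (0.06 log units) apart, within the scatter of two such steps Replacing the whole group changes no more, with a 1.3-fold higher unbound fraction from compound 2 to compound 4 (0.12 log units; within the scatter) and no change at the digits printed from compound 1 to compound 4 (within the scatter), so every pair among these four compounds stays within the scatter and none can be ranked above another.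

These compounds leave open whether any group at this aromatic carbon can shift the unbound fraction beyond the scatter, for instance an amine or a longer chain in place of the methyl. They also cannot tell whether a methyl on another carbon of the 1H-imidazol-1-yl group would behave as this one does, since all the steps here are too small to separate a real effect from repeat-to-repeat variation.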